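The source may hold more compounds than are shown below. What is called first, only, known or untested is meant among the compounds shown, and "the series" means these compounds.

- compound 1 `C=CCc1cc(O)c(O)c(CN2CCC(C)CC2)c1` gives 41.7%
- compound 2 `C#CCOc1ccc(CC=C)cc1O` gives 23.7%

In a functional assay on MCF7 cells (Homo sapiens) for inhibition, read by MTT assay, with a stated time of 72 h, tested at 30 uM (a higher number here means more inhibition of growth at the concentration tested, a lower number less inhibition of growth), compound 1 stands highest of the two, with compound 2 lower by a gap beyond the scatter. The change phenyl in place of hydrogen on a saturated chain carbon bound to a saturated ring carbon puts phenyl in place of hydrogen on a saturated chain carbon bound to a saturated ring carbon, turning methyl to benzyl and leading from compound 1 to compound 3 `C=CCc1cc(O)c(O)c(CN2CCC(Cc3ccccc3)CC2)c1` in one step. Among the measured compounds shown here, no measured pair shows this change, so the size remains a judgement. In this assay the expected a number 13.3 percentage points higher from compound 1 to compound 3 (beyond the scatter) is a rise, moderately beyond the scatter. The estimated value for compound 3 is 55% (range 35% to 78%).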

Compound 3, percent growth inhibition at one concentration: 70.9%
Compound 3: the middle estimate sits 15.9 percentage points below what was measured; the measured number falls inside the stated range.
By their numbers in this assay, from the lowest: compound 2; then compound 1; then compound 3.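

In this assay methyl to benzyl gives a number 29.2 percentage points higher from compound 1 to compound 3 (beyond the scatter) on the shared core. Among the compounds shown here, this is the only step read so far, and it shows that a phenyl on this saturated chain carbon goes with more growth inhibition, which compound 1 and compound 2 alone could not show. Nothing measured here accounts for the rise.

As far as these compounds go, whether the rise depends on the aromatic ring remains open, as a cyclohexyl group in place of the phenyl would test. Also open, from the compounds shown here alone, is how a longer chain carrying the phenyl, or an amine on it, would read.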